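Adding a chlorine to the fluorophenyl group of compound 1

The compounds below may be only part of what the source reports. "The series", "measured", "known", "first", "only" and "open" are said of these compounds alone.

Compound 1, with the structure `CCOC(=O)C1=Cc2ccccc2OC1(OCc1cn(-c2ccc(F)cc2)nn1)C(F)(F)F`, was tested in a functional assay on A549 cells (Homo sapiens) for inhibition, read by MTT assay, with a stated time of 24 h (a lower number here means a stronger inhibitor, a higher number a weaker inhibitor), where compound 1 gives 7300 nM. A second compound from the same series, compound 2 with the structure `CCOC(=O)C1=Cc2ccccc2OC1(OCc1cc(-c2ccc(Cl)cc2)no1)C(F)(F)F`, has a different ring attached to the shared core; in this assay compound 2 gives 19100 nM. Of these two numbers, compound 1 has the lower one, and the gap to compound 2 is beyond the usual scatter.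

The next compound, compound 3 with the structure `CCOC(=O)C1=Cc2ccccc2OC1(OCc1cn(-c2ccc(F)c(Cl)c2)nn1)C(F)(F)F`, keeps everything in compound 1 except one change: chloro in place of hydrogen on an aromatic carbon. Among the compounds with values here, no measured pair in this set isolates such a change, so its effect is unknown. Compound 3 is expected to remain close to compound 1, with a step of a 1.3-fold lower number from compound 1 to compound 3 (0.12 log units; within the scatter) that may not exceed the scatter. The estimate for compound 3 is 5500 nM, in the range 2000 nM to 15000 nM.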

Compound 3, half-maximal inhibitory concentration: 26300 nM
Estimate against measurement, compound 3: 4.8-fold (0.68 log units) below; measured number above the stated range.
By their numbers in this assay, from the lowest: compound 1; then compounds 2 and 3 (each within the scatter of the next).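

Within the data shown here, replacing hydrogen with chloro, which turns 4-fluorophenyl into 3-chloro-4-fluorophenyl, gives the first single-change comparison in this set: in this assay it produces a 3.6-fold higher number from compound 1 to compound 3 (0.56 log units; beyond the scatter). This shows that the aromatic carbon ortho to the fluoro group is not indifferent to substitution, since adding one chlorine there is enough to weaken inhibition by a modest step. Nothing available for these compounds accounts for that loss.

As far as these compounds go, it remains open whether the loss is particular to chloro or would also follow another group at this place, such as a methyl group, a methoxy group or an amine. From the compounds shown here alone, it is also open whether chloro at the matching place would act the same way on the aromatic group of compound 2, which is attached through a different ring.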